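Methoxy for chloro on the quinolone core: cytotoxicity notes

The source may hold more compounds than are shown below. What is called first, only, known or untested is meant among the compounds shown, and "the series" means these compounds.

Compound 1 `CNCC1(C)CCN(c2c(F)cc3c(=O)c(C(=O)O)cn(C4CC4)c3c2Cl)C1` carries chloro on the aromatic carbon of the shared core. In a functional assay on V79 cells (Cricetulus griseus) for cytotoxicity, read by colony formation (on this read-out lower numbers stand for stronger inhibition and higher numbers for weaker inhibition), compound 1 gives 23 ug/mL. Compound 2 `CNCC1(C)CCN(c2c(F)cc3c(=O)c(C(=O)O)cn(C4CC4)c3c2OC)C1` differs by methoxy in place of chloro on an aromatic carbon, and in this assay compound 2 gives 120 ug/mL, a step of a 5.2-fold higher number from compound 1 to compound 2 (0.72 log units; beyond the scatter).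

Compound 3 `O=C(O)c1cn(C2CC2)c2c(Cl)c(N3CCNCC3)c(F)cc2c1=O` differs from compound 1 by piperazin-1-yl in place of 3-methyl-3-((methylamino)methyl)pyrrolidin-1-yl on an aromatic carbon; in this assay compound 3 gives 43 ug/mL, a step of a 1.9-fold higher number from compound 1 to compound 3 (0.27 log units; within the scatter). The two cores therefore differ only in the amine on the aromatic carbon.

Compound 4 `COc1c(N2CCNCC2)c(F)cc2c(=O)c(C(=O)O)cn(C3CC3)c12` is not yet measured. It differs from compound 3 by methoxy in place of chloro on an aromatic carbon. Among the compounds with values here, this is the same kind of change as the one from compound 1 to compound 2, not the same: in compound 1 the place is ortho to a 3-methyl-3-((methylamino)methyl)pyrrolidin-1-yl group (9 heavy atoms), while in compound 3 it is ortho to a piperazin-1-yl group (6 heavy atoms); the rest of the place description is alike.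

Within the data shown here, with a single precedent, the expected step for compound 4 in this assay is a 4.7-fold higher number from compound 3 to compound 4 (0.67 log units; beyond the scatter), set beside the one precedent, because compound 1 to compound 2 gave a 5.2-fold higher number from compound 1 to compound 2 (0.72 log units; beyond the scatter). The range is taken wide, since compound 3 is the only other core with this amine. Compound 4 is estimated at 200 ug/mL, expected between 80 ug/mL and 500 ug/mL.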

Compound 4, half-maximal inhibitory concentration: 82 ug/mL
For compound 4 the middle estimate is 2.4-fold (0.39 log units) above the measured one; measured number inside the range.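

On the core of compound 3, methoxy in place of chloro gives a step of a 1.9-fold higher number from compound 3 to compound 4 (0.28 log units; within the scatter) in this assay, so the step seen on the core of compound 1 does not carry over at the same size: the same change on two cores in this assay, a 5.2-fold higher number (0.72 log units; beyond the scatter) from compound 1 to compound 2 and a 1.9-fold higher number (0.28 log units; within the scatter) from compound 3 to compound 4, 2.7-fold (0.44 log units) apart, beyond the scatter of two such steps

Read along the other edge, piperazin-1-yl in place of 3-methyl-3-((methylamino)methyl)pyrrolidin-1-yl gives a 1.5-fold lower number from compound 2 to compound 4 (0.17 log units; within the scatter) on the methoxy core, and this swap likewise fails to repeat its step from the chloro core: the same change on two cores in this assay, a 1.9-fold higher number (0.27 log units; within the scatter) from compound 1 to compound 3 and a 1.5-fold lower number (0.17 log units; within the scatter) from compound 2 to compound 4, 2.7-fold (0.44 log units) apart, beyond the scatter of two such steps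

The four compounds form a single square, so these two gaps are one observation seen from two sides: they show that, within this set, the size of the methoxy-for-chloro step depends on the amine present, but they do not give a cause, nor show which of the two sizes would hold on a further core.

Open, from the compounds shown here alone, is how a hydrogen or a fluoro group on that aromatic carbon would stand against chloro and methoxy in this assay, and whether an ethoxy group would follow methoxy. Also open, going by these compounds, is whether a third amine, such as a morpholin-4-yl or 3-aminopyrrolidin-1-yl group, would give the larger step, the smaller step or neither for methoxy in place of chloro.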